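Methoxy for Amino on a Diphosphate Nucleotide

A few compounds are considered here, and "the series" means these few. Any claim that something is new, unique, unknown or untested is made for them only; others in the source may bear on it.

Compound 1 `Nc1nc(=O)ccn1[C@@H]1O[C@H](COP(=O)(O)OP(=O)(O)O)[C@@H](O)[C@H]1O` was tested in an in vitro functional assay on 1321-N1 cells for agonist activity at P2Y purinoceptor 6 (Homo sapiens), read by scintillation proximity assay and inositol phosphate accumulation; a lower number here means that less compound is needed, a higher number that more compound is needed for the effect. In this assay compound 1 gives >= 100000 nM, which is a limit of the assay and not a number. Compound 2 `Nc1nc(=O)ccn1[C@@H]1O[C@H](COP(=O)(O)O)[C@@H](O)[C@H]1O` gives > 100000 nM, also a limit. Compound 3 `CSc1nc(=O)ccn1[C@@H]1O[C@H](COP(=O)(O)O)[C@@H](O)[C@H]1O` gives > 100000 nM, again a limit. The step that the two limits leave unreadable from compound 1 to compound 2 and the step that the two limits leave unreadable from compound 2 to compound 3 therefore carry no readable size. Compound 4 `COc1nc(=O)ccn1[C@@H]1O[C@H](COP(=O)(O)OP(=O)(O)O)[C@@H](O)[C@H]1O` differs from compound 1 by methoxy in place of amino on an aromatic carbon. For the measured compounds named here, no measured step involves a methoxy group, and compound 1 itself rests on (the limit of >= 100000 nM in this assay, at which 1 of the 3 values shown sits). The step of a number no higher from compound 1 to compound 4 (the limit leaves the size open) is expected to stay within the scatter. Compound 4 is estimated at 100000 nM, between 30000 nM and 300000 nM.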

Compound 4, half-maximal effective concentration: 1370 nM
The estimate for compound 4 lay 73-fold (1.86 log units) above the measured number; measured number outside the range, below it.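

For the compounds shown here, this position, between two ring nitrogen atoms, clearly matters: with the diphosphate kept, methoxy in place of amino gives an at least 72-fold lower number from compound 1 to compound 4 (1.86 log units; beyond the scatter) in this assay, the first readable step here, as the earlier steps cannot be read. On these data alone, compound 1 stands at a limit and not a number (>= 100000 nM), so the full size of this step stays open.

The compounds shown do not tell why methoxy has this effect, or whether it would hold on the shorter phosphate chain of compound 2. As far as these compounds go, whether ethoxy or a longer chain at this position would do the same also remains open.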